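A few compounds are considered here, and "the series" means these few. Any claim that something is new, unique, unknown or untested is made for them only; others in the source may bear on it.

Measured compounds:
- compound 1 `N#CC1=C(N)N(c2ccc(S(N)(=O)=O)cc2)C2=C(CCCC2)C1c1ccccc1`, 10%
- compound 2 `N#CC1=C(N)N(c2ccc(S(N)(=O)=O)cc2)C2=C(CCCC2)C1c1ccccc1O`, 40%

In a functional assay on Ehrlich cells (Mus musculus) for cytotoxicity, read by trypan blue exclusion, with a stated time of 2 h, tested at 25 ug/mL (on this read-out lower numbers stand for a weaker effect and higher numbers for a stronger effect at the one concentration tested), compound 1 gives 10% and compound 2 gives 40%. Among the measured compounds shown here, compound 2 stands highest of the two numbers; the only measured step runs a number 30 percentage points higher from compound 1 to compound 2 (beyond the scatter), hydroxy in place of hydrogen on an aromatic carbon.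

Compound 3 `N#CC1=C(N)N(c2ccc(S(N)(=O)=O)cc2)C2=C(CCCC2)C1c1ccc(O)cc1` differs from compound 2 by 4-hydroxyphenyl in place of 2-hydroxyphenyl on a saturated ring carbon. The hydroxy remains; only its position on the phenyl changes. For the measured compounds named here, the step of a number 30 percentage points higher from compound 1 to compound 2 (beyond the scatter) bears on the presence of the hydroxy, not on where it sits, so no measured step speaks directly to this change. The count of donors and acceptors is unchanged between compound 2 and compound 3. The expectation is therefore a step of no clear direction and within the scatter, a number 5 percentage points lower from compound 2 to compound 3 (within the scatter), with wide uncertainty. Compound 3 is estimated at 35%, in the range 15% to 60%, in this assay.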

Compound 3, a percentage reported as activity, at one concentration (the size of the read-out at that concentration, not a potency): 42%
Estimate against measurement, compound 3: 7 percentage points below, and the stated range covers the measured number.
By their numbers in this assay, from the lowest: compound 1; then compounds 2 and 3 (each within the scatter of the next).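

In this assay, moving the hydroxy around the phenyl on the saturated ring carbon, from 2-hydroxyphenyl to 4-hydroxyphenyl, gives a step within the scatter (a number 2 percentage points higher from compound 2 to compound 3 (within the scatter)), so these two placements cannot be told apart. The rise over the phenyl of compound 1 appears again with the 4-hydroxyphenyl group (a number 32 percentage points higher from compound 1 to compound 3 (beyond the scatter)), so across these three compounds the higher number goes with the presence of the hydroxy, in either of the two placements. Nothing measured here accounts for that rise.

As far as these compounds go, it remains open whether a methoxy, an amine or a carboxylic acid on the phenyl would give a similar number. From the compounds shown here alone, with a single tested concentration, the size of the effect of compound 2 and compound 3 at any other concentration also remains open.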